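A few compounds are considered here, and "the series" means these few. Any claim that something is new, unique, unknown or untested is made for them only; others in the source may bear on it.

Measured so far in an assay on isolated protein for inhibition of Rho-associated protein kinase 2 (Homo sapiens), read by radiometric assay; on this read-out higher numbers stand for weaker inhibition and lower numbers for stronger inhibition:
compound 1, `NCc1ccc(C(=O)Nc2ccncc2)cc1-c1cccc(C(=O)OCC2CCCCC2)c1`, gives 48 nM
compound 2, `NCc1ccc(C(=O)Nc2ccncc2F)cc1-c1cccc(C(=O)OCC2CCCO2)c1`, gives 2.5 nM

Of these two numbers, compound 2 stands lowest; its nearest neighbour, compound 1, shows a markedly higher number, and that gap lies well beyond the usual scatter of this assay. The two structures differ in more than one place, so their values are set side by side only as they stand.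

Compound 3, `NCc1ccc(C(=O)Nc2ccncc2F)cc1-c1cccc(C(=O)OCC2CCCC2)c1`, has not yet been measured. It differs from compound 2 in one place: cyclopentyl in place of oxolan-2-yl on a saturated chain carbon bound to an oxygen next to a carbonyl group. For the measured compounds named here, no measured pair of this kind is available here. The change trades a ring with one hetero atom for a ring of carbon only, and on the numbers at hand such a swap is expected to move the read-out little. Compound 3 is expected to give 4 nM, within 1.5 nM to 12 nM. The step from compound 2 to compound 3 is therefore expected to be a 1.6-fold higher number from compound 2 to compound 3 (0.20 log units; within the scatter), a small rise that need not exceed the usual scatter.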

Compound 3, half-maximal inhibitory concentration: 13 nM
Compound 3: the middle estimate sits 3.3-fold (0.51 log units) below what was measured, outside the stated range (above it).
By their numbers in this assay, from the lowest: compound 2; then compound 3; then compound 1.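

In this assay, for the compounds shown here, the change of oxolan-2-yl to cyclopentyl, on a saturated chain carbon bound to an oxygen next to a carbonyl group, gives the first step that can be read at a single place: a 5.2-fold higher number from compound 2 to compound 3 (0.72 log units; beyond the scatter) and it lies beyond the usual scatter. The read-out at this position therefore tells apart two five-membered rings of equal heavy-atom count, one with a hetero atom and one of carbon only, and the carbon ring carries the higher number. Nothing available here accounts for the size or direction of this step.

The compounds shown leave open how a ring nitrogen, as in pyrrolidin-2-yl, or an open chain such as 2-methoxyethyl would read at this place. They also leave open whether the same step would appear on the core of compound 1.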